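Replacing the Ring Amine with a Simple Aminoethyl Group

The source may hold more compounds than are shown below. What is called first, only, known or untested is meant among the compounds shown, and "the series" means these compounds.

Compound 1 `CN1CCCC[C@H]1[C@H]1COC(c2ccccc2)(c2ccccc2)O1` is the starting point. Within the data shown here, in a functional assay (brain) for displacement of a labelled ligand, with Rattus norvegicus as the target (on this read-out higher numbers stand for weaker inhibition and lower numbers for stronger inhibition), compound 1 gives 4400 nM, the lower of the two numbers measured so far, so it is the stronger of the two inhibitors. Compound 2 `CCCCCCN1CCCC[C@H]1[C@H]1COC(c2ccccc2)(c2ccccc2)O1` carries a longer chain on the ring nitrogen; in this assay compound 2 gives 21200 nM. The step of a 4.8-fold higher number from compound 1 to compound 2 (0.68 log units; beyond the scatter) shows that lengthening that chain weakens inhibition. Compound 3 `C[C@H](N)[C@H]1COC(c2ccccc2)(c2ccccc2)O1` is not yet measured. It differs from compound 1 as follows: 1-aminoethyl in place of 1-methylpiperidin-2-yl on a saturated ring carbon. Among the measured compounds shown here, no measured step matches this change; the only known step, a 4.8-fold higher number from compound 1 to compound 2 (0.68 log units; beyond the scatter), alters a different part of the amine and gives just a weak hint that changes around the amine tend to weaken inhibition. The expected step is therefore uncertain, a 1.8-fold higher number from compound 1 to compound 3 (0.26 log units; within the scatter), and most likely a somewhat higher number. Compound 3 is estimated to give 8000 nM in this assay, within 2000 nM to 40000 nM.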

Compound 3, inhibition constant: 607 nM
The estimate for compound 3 lay 13-fold (1.12 log units) above the measured number, and the stated range ends above it.
By their numbers in this assay, from the lowest: compound 3; then compound 1; then compound 2.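

With a 7.2-fold lower number from compound 1 to compound 3 (0.86 log units; beyond the scatter) in this assay this position is shown not to need the 1-methylpiperidin-2-yl group, since the smaller, ring-free 1-aminoethyl group goes with stronger inhibition. The earlier step changed only the chain on the ring nitrogen, so it could not show what happens when the ring itself leaves, and its weakening does not carry over to this change. Nothing available here explains the stronger inhibition.

This single change removes the ring and also adds a hydrogen-bond donor, so the compounds shown cannot separate these two differences. On these data alone, it also remains open whether a 1-(methylamino)ethyl group, which has a methyl on the amine, or a longer chain such as 1-aminopropyl would keep the stronger inhibition seen with compound 3.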